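From cyclohexylamino to dipropylamino: a step without a readable baseline

A few compounds are considered here, and "the series" means these few. Any claim that something is new, unique, unknown or untested is made for them only; others in the source may bear on it.

Compounds measured in a functional assay on MGC-803 cells (Homo sapiens) for inhibition, read by sulforhodamine B assay; on this read-out lower numbers stand for stronger inhibition and higher numbers for weaker inhibition:
Compound 1 `O=C1C(N2CCCCC2)=CC(=O)c2c1nc1n2[C@H]2OC[C@@H](O)[C@H]2OC1`: > 4000 nM
Compound 2 `O=C1C(NC2CCCCC2)=CC(=O)c2c1nc1n2[C@H]2OC[C@@H](O)[C@H]2OC1`: > 8000 nM

Compound 2 has no number, only the limit > 8000 nM.
Compound 1 also has only a limit, > 4000 nM.

The next compound is compound 3 `CCCN(CCC)C1=CC(=O)c2c(nc3n2[C@H]2OC[C@@H](O)[C@H]2OC3)C1=O`, which keeps the shared core. The change is dipropylamino in place of cyclohexylamino on a double-bonded ring carbon. In words, dipropylamino stands in place of cyclohexylamino on a double-bonded ring carbon.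

Going by the values given here, the one measured step that bears on this is a step that the two limits leave unreadable from compound 1 to compound 2, with cyclohexylamino in place of piperidin-1-yl on a double-bonded ring carbon. It offers no size to carry over, so no direction can be read for this assay, and no shift beyond the scatter is expected. The expected change is a number no higher from compound 2 to compound 3 (the limit leaves the size open). For compound 3 the estimated value is 8000 nM, with an expected range from 3000 nM to 20000 nM.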

Compound 3, half-maximal inhibitory concentration: > 16000 nM
Compound 3: only a limit was reported; the forecaster's own chance of this, stated with the estimate: 60%; middle value at least 2.0-fold (0.30 log units) from the limit.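

In this assay compound 3 gives only a limit, > 16000 nM. Going by these compounds alone, compound 1, compound 2 and compound 3 all carry limits alone, so no step among them can be read. The compounds shown leave open how strongly any of the three inhibits, and whether their amino groups differ at all.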